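This account rests on a few compounds, and the source may have more. Where it says the series, first, only, none or still open, it means among the compounds named here.

Measured so far in a functional assay on HL-60 cells (Homo sapiens) for cytotoxicity, read by WST assay, with a stated time of 48 h; on this read-out higher numbers stand for weaker inhibition and lower numbers for stronger inhibition:
compound 1 `O[C@@H](c1ccccc1)[C@H]1CO[C@H](c2ccccc2)[C@@H](C/C=C/c2ccccn2)C1` gives 36400 nM
compound 2 `COc1ccc(/C=C/C[C@@H]2C[C@@H]([C@@H](O)c3ccc(OC)c(OC)c3)CO[C@H]2c2ccc(OC)c(OC)c2)cc1OC` gives 26000 nM
compound 3 `C=CC[C@H]1C[C@@H]([C@@H](O)c2ccccc2)CO[C@@H]1c1ccccc1` gives 36000 nM

Compound 2 holds the lowest of the three numbers, but its gaps to compound 3 and to compound 1 are both within the scatter, so no order among the three is established. Compound 4 `COc1ccc(/C=C/C[C@H]2C[C@@H]([C@@H](O)c3ccc(OC)c(OC)c3)CO[C@@H]2c2ccc(OC)c(OC)c2)cc1OC` has the same atoms and bonds as compound 2 and differs only in configuration: the two compounds have the same atoms and bonds and differ only in configuration as drawn: 2 of 5 stereo elements differ; a stereocentre at a saturated ring carbon is drawn R in compound 2 and S in compound 4; a stereocentre at a saturated ring carbon is drawn R in compound 2 and S in compound 4. For the measured compounds named here, the single measured step, a 1.0-fold lower number from compound 1 to compound 3 (0.00 log units; within the scatter), concerns a chain substituent and stays within the scatter; no measured step inverts a stereocentre, so nothing here bears directly on the change from compound 2 to compound 4. The three values cluster closely whatever the substitution, which points to a number near that of compound 2, 26000 nM, with the direction left open. Compound 4 is expected at 30000 nM (range 10000 nM to 90000 nM), an expected step of a 1.2-fold higher number from compound 2 to compound 4 (0.06 log units; within the scatter).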

Compound 4, half-maximal inhibitory concentration: 34700 nM
Estimate against measurement, compound 4: 1.2-fold (0.06 log units) below, within the range that was stated.
By their numbers in this assay, from the lowest: compounds 2, 4, 3 and 1 (each within the scatter of the next).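

In this assay, for the compounds shown here, the first measured change of configuration gives a 1.3-fold higher number from compound 2 to compound 4 (0.13 log units; within the scatter). This comparison involves no substituent change: the fact that compounds 2 and 4 differ only in the configuration as drawn. Inverting these two saturated ring carbons together therefore leaves the values of this pair inside the scatter, so the drawn configuration at these centres does not separate them.

Open, on these data alone, is whether inverting either stereocentre alone would give the same result, as the two change together here. Also open, as far as these compounds go, is whether an amine or a carboxylic acid in place of the 2-(pyridin-2-yl)ethenyl of compound 1 would move the value beyond the scatter.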